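Swapping the ring on the sulfur in a cytotoxicity series

The source may hold more compounds than are shown below. What is called first, only, known or untested is meant among the compounds shown, and "the series" means these compounds.

Of the compounds shown here, three built on one shared core have been measured, and a fourth awaits its number. Compound 1 `Cn1c(-c2ccc(NC(=O)CSc3nc4ccccc4o3)cc2)nc(-c2ccccc2)c1-c1ccccc1` gives 79.3% in a functional assay on HT-29 cells (Homo sapiens) for cytotoxicity, read by MTT assay, with a stated time of 24 h, tested at 32 ug/mL; on this read-out lower numbers stand for a weaker effect and higher numbers for a stronger effect at the one concentration tested. Compound 2 `Cn1c(-c2ccc(NC(=O)CSc3nc4cc(Cl)ccc4o3)cc2)nc(-c2ccccc2)c1-c1ccccc1` gives 61.9%, and compound 3 `Cc1nnc(SCC(=O)Nc2ccc(-c3nc(-c4ccccc4)c(-c4ccccc4)n3C)cc2)s1` gives 87.1%. Among these three, compound 1 stands second highest: the step of a number 7.8 percentage points higher from compound 1 to compound 3 (within the scatter) stays within the scatter, while the step of a number 17.4 percentage points lower from compound 1 to compound 2 (beyond the scatter) lies beyond it.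

Compound 4 `Cn1c(-c2ccc(NC(=O)CSC3=NCCS3)cc2)nc(-c2ccccc2)c1-c1ccccc1` differs from compound 1 only at the sulfur: a group of 5 heavy atoms (3 carbon, 1 nitrogen, 1 sulfur; one five-membered non-aromatic ring with 2 hetero atoms) in place of a group of 9 heavy atoms (7 carbon, 1 nitrogen, 1 oxygen; one five-membered aromatic ring with 2 hetero atoms, one six-membered aromatic ring of carbon only), on a sulfur. The measured step that most resembles this is the exchange of the ring on the sulfur, where the step of a number 7.8 percentage points higher from compound 1 to compound 3 (within the scatter) was within the scatter; the step of a number 25.2 percentage points higher from compound 2 to compound 3 (beyond the scatter) was larger but starts from a compound carrying a chloro group. Since a change of the ring on the sulfur has so far left the read-out nearly unchanged, the expected step for compound 4 is small, a number 5.3 percentage points lower from compound 1 to compound 4 (within the scatter), with no clear direction. Compound 4 is therefore estimated at 74%, expected to lie between 55% and 90%.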

Compound 4, a percentage reported as activity, at one concentration (the size of the read-out at that concentration, not a potency): 59.4%
Beside the measured number, compound 4's estimate is 14.6 percentage points above it; measured number inside the range.
By their numbers in this assay, from the lowest: compounds 4 and 2 (each within the scatter of the next); then compounds 1 and 3 (each within the scatter of the next).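

The ring on the sulfur is not free to change after all: in this assay, the non-aromatic five-membered ring gives a number 19.9 percentage points lower from compound 1 to compound 4 (beyond the scatter) and a number 27.7 percentage points lower from compound 3 to compound 4 (beyond the scatter), both beyond the scatter, whereas the earlier swap between two aromatic rings stayed within it. Losing aromaticity does not sort the series by itself, since compound 2 keeps its aromatic 5-chloro-1,3-benzoxazol-2-yl group and still shows a number 2.5 percentage points lower from compound 2 to compound 4 (within the scatter), a step within the scatter. Nothing available here explains why this ring behaves differently from the 1,3-benzoxazol-2-yl group.

Going by these compounds, whether it is the missing aromatic ring or the smaller group that matters stays open. So does the effect of an open chain on the sulfur, such as an ethyl group or a short chain ending in an amine.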